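Notes on the trifluoromethyl-to-cyano step in this series

A few compounds are considered here, and "the series" means these few. Any claim that something is new, unique, unknown or untested is made for them only; others in the source may bear on it.

Compound 3 `Fc1ccc2ncnc(Nc3cccc(C(F)(F)F)c3)c2c1` stands only at a limit: in a functional assay on HEK293 cells for antagonist activity at metabotropic glutamate receptor 5 (Rattus norvegicus), read by calcium flux (a lower number here means a stronger inhibitor, a higher number a weaker inhibitor), compound 3 gives > 10000 nM, a limit of the assay and not a number. Compound 1 `Fc1ccc2ncnc(Nc3ccccc3)c2c1` likewise gives > 10000 nM, again a limit. For the measured compounds named here, compound 2 `Cc1cccc(Nc2ncnc3ccc(F)cc23)c1` gives 1350 nM, the one numerical reading in the set. The measured steps are an at least 7.4-fold lower number from compound 1 to compound 2 (0.86 log units; beyond the scatter) and an at least 7.4-fold higher number from compound 2 to compound 3 (0.86 log units; beyond the scatter); for the remaining pair there is a step that the two limits leave unreadable from compound 1 to compound 3. Two of the three readings share (the limit of > 10000 nM in this assay, at which 2 of the 3 values shown sit). Compound 4 `N#Cc1cccc(Nc2ncnc3ccc(F)cc23)c1` arises through (cyano in place of trifluoromethyl on an aromatic carbon). Going by the values given here, no measured step swaps trifluoromethyl for cyano, so the steps only frame the outcome: methyl yields a number, hydrogen and trifluoromethyl do not. Compound 4 is expected to give 5000 nM, between 1500 nM and 20000 nM, meaning an expected at least 2.0-fold lower number from compound 3 to compound 4 (0.30 log units; that floor lies within the scatter).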

Compound 4, half-maximal inhibitory concentration: 1370 nM
Estimate against measurement, compound 4: 3.6-fold (0.56 log units) above; the measured number lies below the stated range.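

an at least 7.2-fold lower number from compound 3 to compound 4 (0.86 log units; beyond the scatter) and an at least 7.2-fold lower number from compound 1 to compound 4 (0.86 log units; beyond the scatter) are both floors, each resting on a limit of the assay, so in this assay a numerical reading on this aromatic carbon is no longer tied to methyl. With a 1.0-fold higher number from compound 2 to compound 4 (0.01 log units; within the scatter) there is no separating cyano, with its triple bond and hydrogen-bond acceptor, from methyl at this position.

As far as these compounds go, whether an amine or a carboxylic acid here would also give a number stays open. Compound 1 and compound 3 cannot be read against each other, as each gives only a limit of the assay: the limit of > 10000 nM in this assay, at which 2 of the 4 values shown sit.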